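Extending a Phenol Oxygen with a Basic Side Chain

A few compounds are considered here, and "the series" means these few. Any claim that something is new, unique, unknown or untested is made for them only; others in the source may bear on it.

Compound 1, `CN(C)C1CCN(C(=O)CCCOc2cc(C(=O)N3CCCCc4sccc43)ccc2NC(=O)c2ccccc2-c2ccccc2)CC1`: 3 nM
Compound 2, `CN1CCN(C(=O)CCCOc2cc(C(=O)N3CCCCc4sccc43)ccc2NC(=O)c2ccccc2-c2ccccc2)CC1`: 1 nM
Compound 3, `O=C(Nc1ccc(C(=O)N2CCCCc3sccc32)cc1O)c1ccccc1-c1ccccc1`: < 10 nM

All three share one core and were tested in an assay on adrenal medulla for inhibition of Vasopressin V2 receptor (Rattus norvegicus), read by radioligand binding; on this read-out lower numbers stand for stronger inhibition and higher numbers for weaker inhibition. Compound 1 gives 3 nM and compound 2 gives 1 nM, so the step of a 3.0-fold lower number from compound 1 to compound 2 (0.48 log units; beyond the scatter) follows from exchanging one basic ring for another at the end of the amide-linked side chain. Compound 3 carries a bare hydroxy group where the others carry that chain. For compound 3 this assay reports only a limit, < 10 nM, not a number (the limit of < 10 nM in this assay, at which 1 of the 3 values shown sits). Because of that limit the step that the limit leaves unreadable from compound 2 to compound 3 cannot be sized, and it is unclear whether removing the chain costs anything at all.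

Compound 4, `CN1CCCN(CCCOc2cc(C(=O)N3CCCCc4sccc43)ccc2NC(=O)c2ccccc2-c2ccccc2)CC1`, differs from compound 3 by 3-(4-methyl-1,4-diazepan-1-yl)propyl in place of hydrogen on an oxygen on an aromatic ring. The nearest guide is that compounds 1 and 2, which also place a basic amine-bearing chain on that oxygen, both sit among the strongest values seen here. Compound 4 is therefore expected to land in the same low region, with the step that the limit leaves unreadable from compound 3 to compound 4 estimated to stay within the scatter. The estimate for compound 4 is 3 nM, with a range from 0.8 nM to 15 nM.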

Compound 4, half-maximal inhibitory concentration: < 1 nM
Compound 4: only a limit was reported; the forecaster's own chance of this, stated with the estimate: 30%; at least 3.0-fold (0.47 log units) between middle value and limit.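

In this assay, compound 4 is reported only as a limit, < 1 nM. For the compounds shown here, the one comparison of readable size is an at least 3.0-fold lower number from compound 1 to compound 4 (0.47 log units; beyond the scatter), which shows that this oxygen on the aromatic ring can carry a 3-(4-methyl-1,4-diazepan-1-yl)propyl chain, with a seven-membered ring and no carbonyl in the chain, and still give a lower number than compound 1, whose chain has a carbonyl. A direction without a size comes from a number no higher from compound 2 to compound 4 (the limit leaves the size open), and this step gives no order beyond that. The step from compound 3 to compound 4 cannot be read because compound 4 has no exact value, and the same applies to compound 3, so the gain over the bare hydroxy group cannot be sized: the limit of < 1 nM in this assay, at which 1 of the 4 values shown sits.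

Compound 4 differs from compound 1 in both the ring and the carbonyl at once, so these compounds do not show which of the two changes matters. Going by these compounds, it also remains open how this position would respond to a chain ending in a carboxylic acid or a morpholin-4-yl ring, or to a 3-(4-methylpiperazin-1-yl)propyl chain, which would compare the two ring sizes directly.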